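Thiosemicarbazone series: aryl exchange from compound 1 to compound 4

A few compounds are considered here, and "the series" means these few. Any claim that something is new, unique, unknown or untested is made for them only; others in the source may bear on it.

compound 1 `Cc1ccc2c(c1)/C(=N/NC(=S)N/N=C/c1c(F)cccc1Cl)C(=O)N2`: 1510 nM
compound 2 `COc1ccc(/C=N/NC(=S)N/N=C2\C(=O)Nc3ccc(Br)cc32)c(OC)c1`: > 50000 nM (a limit)
compound 3 `O=C1Nc2ccc(Br)cc2/C1=N/NC(=S)N/N=C/c1c(F)cccc1Cl`: 1610 nM

In a functional assay on HeLa cells (Homo sapiens) for inhibition, read by MTT assay (a lower number here means a stronger inhibitor, a higher number a weaker inhibitor), compound 1 gives 1510 nM and stands lowest of the two numbers in the set, with compound 3 nearest at 1610 nM. Among the measured compounds shown here, the single measured step, a 1.1-fold higher number from compound 1 to compound 3 (0.03 log units; within the scatter), concerns the core and stays within the scatter. For compound 2 this assay reports only a limit, > 50000 nM, which is the limit noted as the limit of > 50000 nM in this assay, at which 1 of the 3 values shown sits. Compound 2 and compound 3 share a core and differ only in the aryl group; compound 3 yields a number where compound 2 yields only a limit.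

Compound 4 `Cc1ccc2c(c1)/C(=N/NC(=S)N/N=C/c1ccc(Br)cc1)C(=O)N2` differs from compound 1 by 4-bromophenyl in place of 2-chloro-6-fluorophenyl on a carbon with a double bond to nitrogen. For the measured compounds named here, no measured step covers this exchange; the only measured step touches the core, not the aryl group. The pair of compound 2 and compound 3 shows that an aryl exchange on this core can carry the read-out from a number to a limit, so a move toward a weaker number is expected, of uncertain size. Compound 4 is estimated at 8000 nM, within 1500 nM to 50000 nM. The expected step is a 5.3-fold higher number from compound 1 to compound 4 (0.72 log units; beyond the scatter).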

Compound 4, half-maximal inhibitory concentration: > 50000 nM
Compound 4 gave a limit, no number; the forecaster's own chance of this, stated with the estimate: 30%; middle value at least 6.2-fold (0.79 log units) from the limit.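

In this assay, the exchange of 2-chloro-6-fluorophenyl for 4-bromophenyl on the carbon with a double bond to nitrogen gives an at least 33-fold higher number from compound 1 to compound 4 (1.51 log units; beyond the scatter), so this position is now shown to matter on the core of compound 1, whereas the earlier step touched only the core. The result for compound 4 is a limit, not a number, so the step has a lower bound only. Compound 1 and compound 3 carry 2-chloro-6-fluorophenyl and give numbers, while compound 2 and compound 4 carry other aryl groups and give only limits: the limit of > 50000 nM in this assay, at which 2 of the 4 values shown sit.

From the compounds shown here alone, it remains open whether the chlorine, the fluorine or both of them keep a number on the shared core. Equally open, going by these compounds, is how a plain phenyl, or a phenyl bearing an amine or a carboxylic acid, would read out at this position.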